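A few compounds are considered here, and "the series" means these few. Any claim that something is new, unique, unknown or untested is made for them only; others in the source may bear on it.

Two compounds built on a shared core were examined in a functional assay on Ehrlich cells (Mus musculus) for cytotoxicity, read by trypan blue exclusion, with a stated time of 2 h, tested at 100 ug/mL; a lower number here means a stronger effect, a higher number a weaker effect of the compound at the concentration tested. Compound 1 `CC(=O)N(C(C)=O)c1c(C#N)[n+]([O-])c2cc(Cl)ccc2[n+]1[O-]` gives 0% in this assay. Compound 2 `Cc1c(C(=O)N=[N+]=[N-])[n+]([O-])c2cc(Cl)ccc2[n+]1[O-]` gives 59.1% in this assay. Among the two numbers, compound 2 stands with the higher one; the number of compound 1 lies far below it, a gap well beyond the scatter, so compound 2 shows the weaker effect at the concentration tested. Among the compounds with values here, the two compounds differ from each other in more than one place, so no single step between measured compounds is available to show how any one change acts.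

Compound 3 `COc1ccc2c(c1)[n+]([O-])c(C(=O)N=[N+]=[N-])c(C)[n+]2[O-]` has not yet been measured. It differs from compound 2 at one position: methoxy in place of chloro on an aromatic carbon. Within the data shown here, nothing among the measured compounds tells how methoxy in place of chloro at this position shifts the read-out, so the expectation for compound 3 rests on the number of compound 2 alone.

Compound 3 is expected to give 60% in this assay, with a range from 40% to 80%. That estimate means an expected step of a number 0.9 percentage points higher from compound 2 to compound 3 (within the scatter), a step of no size beyond the scatter in either direction.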

Compound 3, a percentage reported as activity, at one concentration (the size of the read-out at that concentration, not a potency): 1.3%
The estimate for compound 3 lay 58.7 percentage points above the measured number; measured number below the stated range.
By their numbers in this assay, from the lowest: compounds 1 and 3 (each within the scatter of the next); then compound 2.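

In this assay, within the data shown here, the one change of methoxy in place of chloro on an aromatic carbon, meta to a fused ring and para to a fused ring, gives the first step that can be read in this set: a large move of a number 57.8 percentage points lower from compound 2 to compound 3 (beyond the scatter), toward the stronger effect at the concentration tested. The earlier compounds shown here could not show this, as they differ in more than one place; this pair shows that the read-out is not indifferent to the group at this position, and that exchanging chloro for methoxy alone is enough to move it well beyond the scatter. Nothing measured here on either group bears on this step, so the data give no account of what lies behind it.

The compounds shown leave open whether another group at this position, such as an amine, a carboxylic acid or a longer alkoxy chain, would read like methoxy or like chloro. They also leave open whether the same exchange would move the read-out this far with other groups elsewhere on the shared core, as this rests on a single pair at a single concentration.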